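A few compounds are considered here, and "the series" means these few. Any claim that something is new, unique, unknown or untested is made for them only; others in the source may bear on it.

Series notes. Three measured compounds share one core and differ only in the aryl group carried on the amine nitrogen. Compound 1 `FC(F)(F)c1ccc(CSc2nc(Nc3ccccc3Cl)c3ccccc3n2)cc1` gives 20400 nM in a functional assay on PC-3 cells (Homo sapiens) for cytotoxicity, read by MTT assay, with a stated time of 72 h; a lower number here means a stronger inhibitor, a higher number a weaker inhibitor. Compound 2 `FC(F)(F)c1ccc(CSc2nc(Nc3cccc(C(F)(F)F)c3)c3ccccc3n2)cc1` gives 12900 nM in this assay, and compound 3 `FC(F)(F)c1ccc(CSc2nc(Nc3cccc(Cl)c3)c3ccccc3n2)cc1` gives 13400 nM. The step of a 1.6-fold lower number from compound 1 to compound 2 (0.20 log units; within the scatter) and the step of a 1.5-fold lower number from compound 1 to compound 3 (0.18 log units; within the scatter) both stay within the scatter, as does a 1.0-fold higher number from compound 2 to compound 3 (0.02 log units; within the scatter). Compound 3 stands second highest of the three numbers, with compound 2 nearest and compound 1 furthest, and both of those gaps are within the scatter, so the three numbers cannot be put in any order.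

Compound 4 `FC(F)(F)c1ccc(CSc2nc(Nc3cccc(Br)c3)c3ccccc3n2)cc1` is not yet measured. It differs from compound 3 by bromo in place of chloro on an aromatic carbon. For the measured compounds named here, no measured step exchanges one halogen for another; the only step at the same position, a 1.0-fold higher number from compound 2 to compound 3 (0.02 log units; within the scatter), exchanges trifluoromethyl for chloro and is within the scatter. Every step in the set so far is within the scatter. The expectation for this assay is therefore a step of a 1.0-fold lower number from compound 3 to compound 4 (0.01 log units; within the scatter), that is, no movement beyond the scatter in either direction. Compound 4 is estimated at 13000 nM, with a range from 6500 nM to 26000 nM.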

Compound 4, half-maximal inhibitory concentration: 8680 nM
Estimate against measurement, compound 4: 1.5-fold (0.18 log units) above; low and high end bracket the measured number.
By their numbers in this assay, from the lowest: compounds 4, 2, 3 and 1 (each within the scatter of the next, the first and the last beyond it).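

Bromo in place of chloro, the only halogen exchange in the set, reads a 1.5-fold lower number from compound 3 to compound 4 (0.19 log units; within the scatter) in this assay and bromo in place of trifluoromethyl reads a 1.5-fold lower number from compound 2 to compound 4 (0.17 log units; within the scatter), so at this aromatic carbon the three groups are not told apart by these numbers. For the compounds shown here, the set now holds its only step beyond the scatter, the modest 2.4-fold lower number from compound 1 to compound 4 (0.37 log units; beyond the scatter), but this step exchanges both the halogen and its place on the ring, and the matching steps a 1.6-fold lower number from compound 1 to compound 2 (0.20 log units; within the scatter) and a 1.5-fold lower number from compound 1 to compound 3 (0.18 log units; within the scatter) stay within the scatter, so it marks a gap between the two ends of the series and no effect of bromo alone. Nothing available on these compounds offers an explanation for that gap.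

A 2-bromophenyl group on the same nitrogen would separate the halogen from its place on the ring, which the present pairs cannot do. On these data alone, whether any group at this aromatic carbon moves the number beyond the scatter from compound 3 also stays open, for instance an amine, a methoxy or a carboxylic acid in place of the halogen.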